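A few compounds are considered here, and "the series" means these few. Any claim that something is new, unique, unknown or untested is made for them only; others in the source may bear on it.

Three compounds of the series share one core. In a functional assay on NCI-H1581 cells (Homo sapiens) for inhibition, read by MTT assay, with a stated time of 48 h, tested at 10 uM (a lower number here means less inhibition, a higher number more inhibition at the concentration tested (going by the name of the read-out)), compound 1 `COc1cc(NC(=O)Nc2cc(Nc3ccc(C)c(C)c3)ncn2)cc(OC)c1` gives 20.1%, the lowest of the three numbers. Compound 2 `COc1ccc(Br)cc1Nc1cc(NC(=O)Nc2c(Cl)cccc2Cl)ncn1` gives 53.3% in this assay, and compound 3 `CC(C)(C)c1ccc(Nc2cc(NC(=O)Nc3c(Cl)cccc3Cl)ncn2)cc1` gives 71.3%; both gaps to compound 1 lie beyond the scatter. No pair of these compounds differs in one place only, so no single step is shown. Compound 4 `COc1cc(NC(=O)Nc2cc(Nc3cc(I)ccc3OC)ncn2)cc(OC)c1` is not yet measured; it differs from compound 1 by 5-iodo-2-methoxyphenyl in place of 3,4-dimethylphenyl on a nitrogen on an aromatic ring. Compound 2 also carries a halogen-bearing methoxyphenyl on that nitrogen and gives 53.3%, which suggests a rise. A step upward of moderate size, a number 15.9 percentage points higher from compound 1 to compound 4 (beyond the scatter), is expected. Compound 4 is estimated at 36%, between 15% and 60%.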

Compound 4, a percentage reported as inhibition, at one concentration (the size of the read-out at that concentration, not a potency): 59%
Compound 4: the middle estimate sits 23 percentage points below what was measured; low and high end bracket the measured number.
By their numbers in this assay, from the lowest: compound 1; then compounds 2 and 4 (each within the scatter of the next); then compound 3.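

For the compounds shown here, this is the first single-place step: with the rest of compound 1 unchanged, 5-iodo-2-methoxyphenyl in place of 3,4-dimethylphenyl gives a number 38.9 percentage points higher from compound 1 to compound 4 (beyond the scatter) in this assay on a nitrogen on an aromatic ring. The group at this position alone can therefore shift the read-out by a large amount. No available evidence explains the rise.

As far as these compounds go, because the iodine and the methoxy enter together, their separate contributions remain open. Also open, from the compounds shown here alone, is how a morpholine or a dimethylamino group on this ring would read.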